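Methoxy for Methyl on a Dichloro Core

This account rests on a few compounds, and the source may have more. Where it says the series, first, only, none or still open, it means among the compounds named here.

Compound 1 `Cc1ccc(-c2c(C#N)[n+]([O-])c3cc(C(F)(F)F)ccc3[n+]2[O-])cc1` and compound 2 `COc1ccc(-c2c(C#N)[n+]([O-])c3cc(C(F)(F)F)ccc3[n+]2[O-])cc1` share a core carrying a trifluoromethyl group and differ at a single aromatic carbon, where the change is methoxy in place of methyl on an aromatic carbon. In a physicochemical assay for lipophilicity, measured as octanol-water partition (a lower number here means a more polar compound, a higher number a more lipophilic compound), compound 1 gives 2.95, and compound 2 gives 2.45. The resulting step, a number 0.50 log units lower from compound 1 to compound 2 (beyond the scatter), is the only measured instance of this change among the compounds shown.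

Compound 3 `Cc1ccc(-c2c(C#N)[n+]([O-])c3cc(Cl)c(Cl)cc3[n+]2[O-])cc1` carries two chlorines on its core where compound 1 carries the trifluoromethyl group; the difference between the two cores is not broken down here. In this assay compound 3 gives 3.1, a number close to that of compound 1 and distinctly higher than that of compound 2.

Compound 4 `COc1ccc(-c2c(C#N)[n+]([O-])c3cc(Cl)c(Cl)cc3[n+]2[O-])cc1` has not yet been measured. It stands to compound 3 as compound 2 stands to compound 1: the change is methoxy in place of methyl on an aromatic carbon, and the place is described in the same words in both pairs, so this is the same change made on the second core. Among the measured compounds shown here, for compound 4 the step from compound 3 in this assay is expected to be a number 0.50 log units lower from compound 3 to compound 4 (beyond the scatter), set beside the earlier one, because a number 0.50 log units lower from compound 1 to compound 2 (beyond the scatter) is the only measured guide for this change. Compound 4 is therefore estimated at 2.6, with a likely range from 2.3 to 2.9.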

Compound 4, partition coefficient: 2.33
Compound 4: middle estimate off by 0.27 log units, on the high side; the range from low to high includes it.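

In this assay, going from 4-methylphenyl to 4-methoxyphenyl on the core with two chlorines gives a number 0.77 log units lower from compound 3 to compound 4 (beyond the scatter), while the same change on the core with the trifluoromethyl group gave a number 0.50 log units lower from compound 1 to compound 2 (beyond the scatter), so both measured pairs move in the same direction and both steps lie beyond the scatter. This shows that the direction of the change carried over from one core to the other in these two pairs, but it does not show that the step has a fixed size, since two pairs are too few to tell whether the size depends on the core, and they say nothing about any other core. Nothing available here bears on why the step takes the size it does on either core.

The compounds shown leave open whether the same direction would hold on a third core, or with a different group in place of the nitrile on the shared core. They also leave open what happens when an ethoxy group, an amine or a carboxylic acid stands on that same aromatic carbon in place of methoxy, on either of the two cores.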